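This account rests on a few compounds, and the source may have more. Where it says the series, first, only, none or still open, it means among the compounds named here.

Compound 1, `CC(c1ccc(-c2ccccc2)c(F)c1)c1nnc2n1N=C(c1ccc(Cl)cc1)CS2`, was tested in a functional assay on SNU-475 cells (Homo sapiens) for inhibition, read by sulforhodamine B assay, with a stated time of 72 h (on this read-out lower numbers stand for stronger inhibition and higher numbers for weaker inhibition), and gave 3800 nM. Compound 2, `CC(C)Cc1ccc(C(C)c2nnc3n2N=C(c2ccc(Br)cc2)CS3)cc1`, gave 10100 nM in this assay. Of these two numbers, compound 1 has the lower one, and its gap to compound 2 is beyond the usual scatter. Compound 3, `COc1ccc(C2=Nn3c(nnc3C(C)c3ccc(-c4ccccc4)c(F)c3)SC2)cc1`, has not yet been measured; its structure follows from compound 1 by a single change: methoxy in place of chloro on an aromatic carbon. Within the data shown here, no measured pair here shows what this change does on the shared core, so there is no step to draw on. One small group is exchanged for another, and nothing in the two measured values points to a large effect in either direction. The expected step of a 1.3-fold higher number from compound 1 to compound 3 (0.12 log units; within the scatter) is therefore small and within the scatter. Compound 3 is estimated to give 5000 nM in this assay, with a likely range from 2000 nM to 12000 nM.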

Compound 3, half-maximal inhibitory concentration: 6700 nM
Compound 3: the middle estimate sits 1.3-fold (0.13 log units) below what was measured; the range from low to high includes it.
By their numbers in this assay, from the lowest: compounds 1, 3 and 2 (each within the scatter of the next, the first and the last beyond it).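

Among these compounds, exchanging 4-chlorophenyl for 4-methoxyphenyl on the shared core gives, in this assay, a 1.8-fold higher number from compound 1 to compound 3 (0.25 log units; within the scatter) and is the first direct comparison at this position. The two compounds cannot be told apart here, so this position can carry either chloro or methoxy with no clear difference in the read-out, even though methoxy adds a heavy atom and a hydrogen-bond acceptor. Nothing measured here gives a reason for this result.

These two groups are the only ones compared at this position, so an amine, a carboxylic acid or a longer chain such as butoxy could behave quite differently. Compound 2 differs from compound 1 in more than one place, which leaves open whether the same exchange would give a similar result alongside its other substituents.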